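Pyrazole in place of thiophene on the imidazoline phenyl ether

This account rests on a few compounds, and the source may have more. Where it says the series, first, only, none or still open, it means among the compounds named here.

The three measured compounds share one core and differ in the aromatic group on one ring carbon. Compound 1 `c1cnc(-c2ccccc2OCC2=NCCN2)nc1` is measured in a functional assay for activation of Alpha-1D adrenergic receptor (Homo sapiens), read by calcium flux (a lower number here means that less compound is needed, a higher number that more compound is needed for the effect), only as a limit, < 100000 nM. Compound 2 `c1ccc(-c2cnccn2)c(OCC2=NCCN2)c1` likewise gives only the limit < 100000 nM. Within the data shown here, compound 3 `c1ccc(-c2ccsc2)c(OCC2=NCCN2)c1` is the one compound with a number, 12.6 nM. The three steps between them, a step that the two limits leave unreadable from compound 1 to compound 2, a step that the limit leaves unreadable from compound 1 to compound 3 and a step that the limit leaves unreadable from compound 2 to compound 3, cannot be sized, since the limit of < 100000 nM in this assay, at which 2 of the 3 values shown sit, hides two of the three values. Compound 4 `c1ccc(-c2cc[nH]n2)c(OCC2=NCCN2)c1` differs from compound 3 in one place: 1H-pyrazol-3-yl in place of thiophen-3-yl on an aromatic carbon. Among the measured compounds shown here, no measured step exchanges one five-membered ring for another, so none bears directly on this change; the measured steps only show that six-membered aromatic groups reach no number while the thiophene does. The estimate for compound 4 is therefore a loss of potency of uncertain size, a 32-fold higher number from compound 3 to compound 4 (1.50 log units; beyond the scatter), and compound 4 is expected at 400 nM, between 30 nM and 20000 nM.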

Compound 4, half-maximal effective concentration: < 100000 nM
Compound 4: no number, only a limit (the forecaster's own chance of this, stated with the estimate: 30%); the middle value lies beyond the limit too.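

In this assay compound 4 gives only a limit, < 100000 nM, so its steps to compound 1, compound 2 and compound 3 cannot be read: the limit of < 100000 nM in this assay, at which 3 of the 4 values shown sit. The compounds shown leave open whether any group other than thiophen-3-yl on this aromatic carbon gives a number in this assay.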